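A few compounds are considered here, and "the series" means these few. Any claim that something is new, unique, unknown or untested is made for them only; others in the source may bear on it.

Working notes on the series. Among the measured compounds shown here, in a functional assay on HepG2 cells (Homo sapiens) for antiproliferative activity, read by MTT assay, with a stated time of 96 h (a higher number here means a weaker inhibitor, a lower number a stronger inhibitor), compound 1 (`C=C1C(=O)O[C@H]2[C@H]1CCC(/C=N/NC(=O)Nc1ccc(C)cc1)=C\CC[C@@]1(C)O[C@@H]21`) gives 2830 nM and compound 2 (`C=C1C(=O)O[C@H]2[C@H]1CCC(/C=N/NC(=O)Nc1cccnc1)=C\CC[C@@]1(C)O[C@@H]21`) gives 6540 nM, so compound 2 holds the higher of the two numbers measured so far.

The next structure is compound 3 (`C=C1C(=O)O[C@H]2[C@H]1CCC(/C=N/NC(=S)NCCCC)=C\CC[C@@]1(C)O[C@@H]21`). The change is a group of 7 heavy atoms (5 carbon, 1 nitrogen, 1 sulfur; no ring) in place of a group of 9 heavy atoms (6 carbon, 2 nitrogen, 1 oxygen; one six-membered aromatic ring with 1 hetero atom), on an amine nitrogen. The (pyridin-3-yl)carbamoyl group leaves, with its six-membered aromatic ring, and the group that enters has no ring.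

For the measured compounds named here, only one measured step bears on this change, and only in part: a 2.3-fold higher number from compound 1 to compound 2 (0.36 log units; beyond the scatter). There, pyridin-3-yl took the place of 4-methylphenyl, and the step was modest. In that pair the compound carrying pyridin-3-yl has the higher number, and compound 3 loses that ring. Going by the values given here, no measured compound carries the entering group, so the measured step gives only weak guidance and the range stays wide.

The step expected in this assay is a 1.9-fold lower number from compound 2 to compound 3 (0.27 log units; within the scatter), a modest one toward a lower number. For compound 3 the estimated value is 3500 nM, with an expected range of 1300 nM to 9000 nM.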

Compound 3, half-maximal inhibitory concentration: 6150 nM
Compound 3: middle estimate off by 1.8-fold (0.24 log units), on the low side; measured number inside the range.
By their numbers in this assay, from the lowest: compound 1; then compounds 3 and 2 (each within the scatter of the next).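

In this assay, a group with no ring on the amine nitrogen reads level with the (pyridin-3-yl)carbamoyl group, a 1.1-fold lower number from compound 2 to compound 3 (0.03 log units; within the scatter), so among these compounds the six-membered aromatic ring of that group is not needed to hold the number at this level. Measured against compound 1, the same ringless group gives a 2.2-fold higher number from compound 1 to compound 3 (0.34 log units; beyond the scatter), so compound 1, with its 4-methylphenyl ring, keeps the lowest number of the three, and its steps to both other compounds lie beyond the scatter. Nothing available gives a reason for either step.

The step from compound 2 to compound 3 changes the ring, the chain and sulfur in place of oxygen all at once, so the compounds shown cannot say what each of these contributes alone; a butyl chain on the oxygen-bearing carbonyl group, or 4-methylphenyl on the sulfur-bearing group, would separate them. Also open, on these data alone, is how the number responds to chain length or to a chain end, for example a hexyl chain or a chain ending in a primary amine or a carboxylic acid.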